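Compound 3: replacing the 2-chloro-4-nitrophenyl group

The source may hold more compounds than are shown below. What is called first, only, known or untested is meant among the compounds shown, and "the series" means these compounds.

Measured in a functional assay on A-431 cells (Homo sapiens) for inhibition, read by sulforhodamine B assay, with a stated time of 2 days; a lower number here means a stronger inhibitor of growth, a higher number a weaker inhibitor of growth:
compound 1 `CC1=C(C(=O)Nc2ccc(C)cc2)C(c2ccc(O)cc2O)NC(Nc2ccc([N+](=O)[O-])cc2Cl)=N1` gives 31900 nM
compound 2 `CC1=C(C(=O)Nc2cccc([N+](=O)[O-])c2)C(c2ccc(O)cc2O)NC(Nc2ccc([N+](=O)[O-])cc2Cl)=N1` gives 3940 nM

Of the two numbers, compound 2 holds the lower, at 3940 nM in this assay. Compound 3 `CC1=C(C(=O)Nc2cccc([N+](=O)[O-])c2)C(c2ccc(O)cc2O)NC(N/N=C/c2cccs2)=N1` keeps the 3-nitrophenyl group on the amide-type nitrogen and differs from compound 2 at one place, on an amine nitrogen, where the 2-chloro-4-nitrophenyl group leaves: a group of 7 heavy atoms (5 carbon, 1 nitrogen, 1 sulfur; one five-membered aromatic ring with 1 hetero atom) in place of a group of 10 heavy atoms (6 carbon, 1 nitrogen, 2 oxygen, 1 chlorine; one six-membered aromatic ring of carbon only), on an amine nitrogen is the full change.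

Within the data shown here, no measured step touches that place. Compound 1 and compound 2 differ only at the amide-type nitrogen, so an 8.1-fold lower number from compound 1 to compound 2 (0.91 log units; beyond the scatter) bears on the new change only indirectly. That step shows the size a single change has reached in this pair, and it gives no direction for compound 3. A step of up to about that size is therefore expected in this assay, with neither direction favoured.

The expected step is a 1.3-fold higher number from compound 2 to compound 3 (0.10 log units; within the scatter) and it remains an estimate. Compound 3 is expected at 5000 nM with an estimated range from 1200 nM to 20000 nM for now.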

Compound 3, concentration for 50% growth inhibition: 19100 nM
For compound 3 the middle estimate is 3.8-fold (0.58 log units) below the measured one; measured number inside the range.
By their numbers in this assay, from the lowest: compound 2; then compounds 3 and 1 (each within the scatter of the next).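

Notes on the amine nitrogen: with the 3-nitrophenyl group held on the amide-type nitrogen, this position now has a measured step in this assay, and the exchange of the 2-chloro-4-nitrophenyl group gives a 4.8-fold higher number from compound 2 to compound 3 (0.69 log units; beyond the scatter) in that assay. The direction at this position is therefore set for this one pair, with the 2-chloro-4-nitrophenyl group on the side of the lower number and the group with one five-membered aromatic ring on the side of the higher. The series now holds two places where a single change moves the number beyond the scatter, the amide-type nitrogen and this amine nitrogen, but no measurement in hand accounts for the step at either place.

The exchange alters the ring, the atom count and the link to the amine nitrogen all at once, so the compounds shown do not separate these parts. Going by these compounds, whether a plain phenyl group or a short alkyl chain on this nitrogen would fall nearer compound 2 or compound 3 remains open, as does whether the step holds with the 4-methylphenyl group on the amide-type nitrogen.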